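This account rests on a few compounds, and the source may have more. Where it says the series, first, only, none or still open, it means among the compounds named here.

Compound 1 `O=C(CCCCC1CCSS1)NCc1cn(CCCOc2ccc3ccc(=O)oc3c2)nn1` is the starting point. Within the data shown here, in a functional assay on PC-12 cells (Rattus norvegicus) for cytotoxicity, read by MTT assay, with stated times of 3 h and 2 h, tested at 50 uM (a lower number here means a weaker effect, a higher number a stronger effect of the compound at the concentration tested), compound 1 gives 43.5%, which is the lowest of the two numbers measured so far. Its nearest neighbour is compound 2 `Cc1cc(=O)oc2cc(OCCCn3cc(CNC(=O)CCCCC4CCSS4)nn3)ccc12`, which in this assay gives 75.4%. Among the measured compounds shown here, the one step measured so far between compounds that differ in a single place is a number 31.9 percentage points higher from compound 1 to compound 2 (beyond the scatter).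

Compound 3 `CC(=O)c1cc2ccc(OCCCn3cc(CNC(=O)CCCCC4CCSS4)nn3)cc2oc1=O` has not yet been tested in this assay. Its change from compound 1 is acetyl in place of hydrogen on an aromatic carbon. For the measured compounds named here, the only measured step that bears on this change is the one from compound 1 to compound 2, which also added a small carbon group to the same fused ring of the shared core and was large. The acetyl in compound 3 sits on a different aromatic carbon from the methyl in compound 2, so that step is a rough guide only. A rise is nevertheless expected for compound 3 because a number 31.9 percentage points higher from compound 1 to compound 2 (beyond the scatter) points upward for a group entering this ring, though the size is uncertain. The expected value of compound 3 in this assay is estimated at 60%, with a range from 38% to 82%. This corresponds to an expected step of a number 16.5 percentage points higher from compound 1 to compound 3 (beyond the scatter).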

Compound 3, a percentage reported as activity, at one concentration (the size of the read-out at that concentration, not a potency): 40.7%
Compound 3: the middle estimate sits 19.3 percentage points above what was measured, and the stated range covers the measured number.
By their numbers in this assay, from the lowest: compounds 3 and 1 (each within the scatter of the next); then compound 2.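

In this assay the acetyl group in place of hydrogen, on this aromatic carbon two atoms from the ring oxygen, gives a number 2.8 percentage points lower from compound 1 to compound 3 (within the scatter) and so leaves compound 3 and compound 1 indistinguishable in this read-out. The earlier result, a number 31.9 percentage points higher from compound 1 to compound 2 (beyond the scatter) with a methyl on a different aromatic carbon, therefore does not extend to every group added to the shared core: of the two additions shown, one step lies beyond the scatter and the other within it. No further data are available to explain why the two additions differ.

The compounds shown leave open whether this contrast follows the group itself or the carbon that carries it, a question that a methyl on the carbon bearing the acetyl in compound 3 would help to settle. Going by these compounds, it also remains open whether another group on this carbon, such as an amine or a carboxylic acid, would stay within the scatter of compound 1 or move clearly away from it.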